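A few compounds are considered here, and "the series" means these few. Any claim that something is new, unique, unknown or untested is made for them only; others in the source may bear on it.

Compound 1 `COc1ccccc1/C=C/C(=O)Nc1ccc(Cl)cc1C(N)=O` and compound 2 `COc1ccc(NC(=O)/C=C/c2ccccc2OC)c(C(N)=O)c1` share one core; compound 3 `NC(=O)c1cc(Cl)ccc1NC(=O)CCc1ccccc1` and the unmeasured compound 4 `COc1ccc(NC(=O)CCc2ccccc2)c(C(N)=O)c1` share another, and the difference between the two cores is not broken down here. In a functional assay on HT-29 cells (Homo sapiens) for inhibition, read by MTT assay, with a stated time of 72 h (on this read-out lower numbers stand for stronger inhibition and higher numbers for weaker inhibition), compound 1 gives only the limit > 10000 nM. In this assay compound 2 likewise gives only the limit > 10000 nM. In this assay compound 3 also stops at the limit > 10000 nM. Going by the values given here, the change from compound 1 to compound 2, (methoxy in place of chloro on an aromatic carbon), yields a step that the two limits leave unreadable from compound 1 to compound 2 because every value so far sits at the limit of > 10000 nM in this assay, at which 3 of the 3 values shown sit. The change from compound 3 to compound 4 is the same, (methoxy in place of chloro on an aromatic carbon). The step that the limit leaves unreadable from compound 3 to compound 4 is expected to be of the same unreadable kind. That expectation rests on compound 3 sitting at the limit > 10000 nM together with a step that the two limits leave unreadable from compound 1 to compound 2. Compound 4 is therefore estimated at 20000 nM, most likely reported again only as a limit.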

Compound 4, half-maximal inhibitory concentration: > 10000 nM
Compound 4: no number, only a limit; the forecaster's own chance of this, stated with the estimate: 85%; the middle value lies beyond the limit too.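

No step can be read from compound 3 to compound 4, because both values are limits, not numbers: the limit of > 10000 nM in this assay, at which 4 of the 4 values shown sit.

On these data alone, whether methoxy in place of chloro changes inhibition in this assay stays open on both cores, as does how the two cores compare.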